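The source may hold more compounds than are shown below. What is called first, only, known or untested is meant among the compounds shown, and "the series" means these compounds.

The measured compounds, read in a functional assay on PC-12 cells (Rattus norvegicus) for cytotoxicity, read by MTT assay, with stated times of 3 h and 2 h, tested at 5 uM; a higher number here means a stronger effect of the compound at the concentration tested, a lower number a weaker effect:
- compound 1, `O=C(CCCCC1CCSS1)NCc1cn(CCCCCOc2ccc3ccc(=O)oc3c2)nn1`, gives 64.5%
- compound 2, `COc1ccc(-c2cc3ccc(OCCCCCn4cc(CNC(=O)CCCCC5CCSS5)nn4)cc3oc2=O)cc1`, gives 41%
- compound 3, `COc1ccc(-c2cc3ccc(OCCCCCn4cc(CNC(=O)CCCCC5CCSS5)nn4)cc3oc2=O)cc1OC`, gives 46.9%

Compound 3 stands second highest of the three numbers in this assay: the step within the scatter is a number 5.9 percentage points higher from compound 2 to compound 3 (within the scatter), whereas the step beyond the scatter is a number 17.6 percentage points lower from compound 1 to compound 3 (beyond the scatter).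

Compound 4, `O=C(CCCCC1CCSS1)NCc1cn(CCCCCOc2ccc3cc(-c4ccc(Cl)c(Cl)c4)c(=O)oc3c2)nn1`, has not yet been measured. It differs from compound 3 in one place: 3,4-dichlorophenyl in place of 3,4-dimethoxyphenyl on an aromatic carbon

For the measured compounds named here, two measured steps bear on this position. Putting an aryl group there gave a number 23.5 percentage points lower from compound 1 to compound 2 (beyond the scatter) and a number 17.6 percentage points lower from compound 1 to compound 3 (beyond the scatter), so an aryl group at this place lowers the read-out against the unsubstituted compound 1. Going by the values given here, exchanging one aryl pattern for another is seen only in a number 5.9 percentage points higher from compound 2 to compound 3 (within the scatter), which stayed within the scatter. Compound 4 keeps an aryl group at this place and merely swaps its pattern, so in this assay the expected step is a number 1.9 percentage points lower from compound 3 to compound 4 (within the scatter), that is, nothing beyond the scatter. For compound 4 the estimate in this assay is therefore 45%, with a range from 30% to 60%.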

Compound 4, a percentage reported as activity, at one concentration (the size of the read-out at that concentration, not a potency): 54.8%
Estimate against measurement, compound 4: 9.8 percentage points below, and the stated range covers the measured number.
By their numbers in this assay, from the lowest: compounds 2, 3, 4 and 1 (each within the scatter of the next, the first and the last beyond it).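

In this assay the 3,4-dichlorophenyl group shows that an aryl group at this place need not set a compound apart from the unsubstituted compound 1: the step is a number 9.7 percentage points lower from compound 1 to compound 4 (within the scatter) and so does not share the clear separation seen with the two methoxy-bearing aryl groups. For the compounds shown here, the pattern on the aryl ring can also matter here, as 3,4-dichlorophenyl in place of 4-methoxyphenyl gives a number 13.8 percentage points higher from compound 2 to compound 4 (beyond the scatter) and is the first exchange of one aryl pattern for another to pass the scatter. Against 3,4-dimethoxyphenyl the same group gives only a number 7.9 percentage points higher from compound 3 to compound 4 (within the scatter) and so is not separated from it.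

Nothing available explains these differences. As far as these compounds go, it remains open whether a single chlorine, an amine or a carboxylic acid on this aryl ring would keep the read-out of compound 4 or move it towards that of compound 2.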